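The source may report more compounds than this note shows. Statements on the series, on what has been measured and on what is new or still open speak of the compounds shown alone.

Compound 1, `CCCCCCCCCCC[C@@H](C[C@@H]1OC(=O)[C@H]1CCCCCC)OC(=O)[C@H](CC(C)C)NC(=O)OC(C)(C)C`: in an assay on membranes from brain for inhibition of Fatty-acid amide hydrolase 1 (Rattus norvegicus) (a higher number here means a weaker inhibitor, a lower number a stronger inhibitor), compound 1 gives > 50000 nM, which is a limit of the assay and not a number. Compound 2, `CCCCCCCCCCC[C@@H](C[C@@H]1OC(=O)[C@H]1CCCCCC)OC(=O)[C@@H](N)CC(C)C`: in this assay compound 2 gives > 50000 nM, again a limit. Compound 3, `CCCCCCCCCCC[C@@H](C[C@@H]1OC(=O)[C@H]1CCCCCC)OC(=O)[C@H](C)NC=O`: in this assay compound 3 gives > 50000 nM, also a limit.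

Compound 3 therefore stands where all three measured compounds stand, at the limit of > 50000 nM in this assay, at which 3 of the 3 values shown sit; no number separates it from compound 1 or compound 2. The step from compound 1 to compound 2, a step that the two limits leave unreadable from compound 1 to compound 2, and the step from compound 2 to compound 3, a step that the two limits leave unreadable from compound 2 to compound 3, cannot be read in size or direction, since both ends of each sit at the limit.

Compound 4, `CCCCCCCCCCC[C@@H](C[C@@H]1OC(=O)[C@H]1CCCCCC)OC(=O)[C@@H](NC(C)=O)C(C)CC`, differs from compound 3 in one place: a group of 9 heavy atoms (7 carbon, 1 nitrogen, 1 oxygen; no ring) in place of a group of 5 heavy atoms (3 carbon, 1 nitrogen, 1 oxygen; no ring), on a carbonyl carbon. Neither measured step bears readably on this change, so no size of step in this assay can be drawn from them, and the three values together only say that the shared core with these esters has not yet shown measurable inhibition. Compound 4 is therefore expected to give 60000 nM, with a step that the limit leaves unreadable from compound 3 to compound 4 that is estimated to remain unreadable, the most likely outcome being another limit rather than a number.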

Compound 4, half-maximal inhibitory concentration: 6600 nM
For compound 4 the middle estimate is 9.1-fold (0.96 log units) above the measured one, outside the stated range (below it).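

For the compounds shown here, compound 4 is the first compound here to give a number rather than a limit, which shows that the group on this carbonyl carbon can change the read-out in this assay while the rest of the structure stays the same. Placing 1-acetamido-2-methylbutyl on that carbon gives an at least 7.5-fold lower number from compound 3 to compound 4 (0.87 log units; beyond the scatter), and the same group in place of 1-amino-3-methylbutyl gives an at least 7.5-fold lower number from compound 2 to compound 4 (0.87 log units; beyond the scatter), both sizes being minimum sizes and the true steps possibly larger. The earlier steps among the other three compounds cannot be read, and those compounds still share a single limit: the limit of > 50000 nM in this assay, at which 3 of the 4 values shown sit.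

What the compounds shown leave open is which feature of 1-acetamido-2-methylbutyl matters, the acetamido group or the branched chain, as each comparison with compound 4 changes both at once. A 1-acetamido-3-methylbutyl or 1-amino-2-methylbutyl group on the same carbon would separate the two, and a longer acyl chain on the nitrogen would show whether the read-out moves further in the same direction.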